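Chain length and terminal amine on the benzimidazolylmethyl amine series

The compounds below may be only part of what the source reports. "The series", "measured", "known", "first", "only" and "open" are said of these compounds alone.

Measured compounds:
compound 1 `NC/C=C\CN(Cc1nc2ccccc2[nH]1)C1CCCc2cccnc21`: 77 nM
compound 2 `NCCN(Cc1nc2ccccc2[nH]1)C1CCCc2cccnc21`: 1370 nM

In a functional assay on CEM-CCRF cells for antagonist activity at C-X-C chemokine receptor type 4 (Homo sapiens), read by calcium flux (a lower number here means a stronger inhibitor, a higher number a weaker inhibitor), compound 2 gives the higher of the two numbers, with compound 1 as the only comparator at 77 nM. For the measured compounds named here, the one step measured so far, an 18-fold higher number from compound 1 to compound 2 (1.25 log units; beyond the scatter), came with shortening of the side chain on the amine nitrogen and loss of the unsaturation, and it was large and well beyond the scatter.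

Compound 3 `CN(C)CCCCN(Cc1nc2ccccc2[nH]1)C1CCCc2cccnc21` extends the chain of compound 2 again: 2-(dimethylamino)ethyl in place of amino on a saturated chain carbon, two bonds along the chain from an amine nitrogen. Going by the values given here, the terminal nitrogen of compound 3 loses its donor hydrogens, which no measured pair addresses, so that part of the change is uncertain. Among the compounds with values here, only the step from compound 1 to compound 2 bears on it, and it points to chain length mattering strongly in this assay. The expected direction is therefore a lower number, of a size estimated as a 6.9-fold lower number from compound 2 to compound 3 (0.84 log units; beyond the scatter). Compound 3 is expected to give about 200 nM in this assay, within a range of 40 nM to 1000 nM.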

Compound 3, half-maximal inhibitory concentration: 87 nM
Estimate against measurement, compound 3: 2.3-fold (0.36 log units) above; the measured number falls inside the stated range.
By their numbers in this assay, from the lowest: compounds 1 and 3 (each within the scatter of the next); then compound 2.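

In this assay, the 2-(dimethylamino)ethyl group in place of amino gives a 16-fold lower number from compound 2 to compound 3 (1.20 log units; beyond the scatter), so the weak number of compound 2 does not extend to this longer saturated chain with its dimethylated terminal amine. Set against the unsaturated chain, 3-(dimethylamino)propyl in place of 3-aminoprop-1-en-1-yl gives a 1.1-fold higher number from compound 1 to compound 3 (0.05 log units; within the scatter): a number at the level of compound 1 is reached here without the double bond and with 0 hydrogen-bond donors on the entering group, although this step changes both features at once. No data on hand account for either step.

As far as these compounds go, the step to compound 3 alters chain length and terminal substitution together, so the share of each remains open; a 4-aminobutyl chain, with the primary amine on the same saturated length, would separate them. From the compounds shown here alone, how far the chain can extend also remains open, and a 5-aminopentyl chain or a 4-(dimethylamino)butyl chain ending instead in a cyclic amine such as piperidine would test the length and the form of the terminal amine.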